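Toward compound 3: trading the sulfate arm for imidazole

The compounds below may be only part of what the source reports. "The series", "measured", "known", "first", "only" and "open" are said of these compounds alone.

Compound 1: `CCCCCCCCCCCC(=O)OC[C@H](CSC[C@@H](N)C(=O)NC(C)(C)CO)OC(=O)CCCCCCCCCCC`, 15500 nM
Compound 2: `CCCCCCCCCCCC(=O)OC[C@H](CSC[C@@H](N)C(=O)NCCOCCOS(=O)(=O)O)OC(=O)CCCCCCCCCCC`, 61 nM

In an assay on HEK293 cells for agonist activity at Toll-like receptor 2 (Homo sapiens) (a higher number here means that more compound is needed for the effect, a lower number that less compound is needed), compound 2 holds the lowest of the two numbers, and the nearest value is that of compound 1. Among the measured compounds shown here, the single measured step, a 250-fold lower number from compound 1 to compound 2 (2.41 log units; beyond the scatter), arose at the amide-type nitrogen and was large. Compound 3, `CCCCCCCCCCCC(=O)OC[C@H](CSC[C@@H](N)C(=O)NCCCn1ccnc1)OC(=O)CCCCCCCCCCC`, has not yet been measured. It differs from compound 2 by (1H-imidazol-1-yl)methyl in place of 2-(sulfooxy)ethoxy on a saturated chain carbon, two bonds along the chain from an amide-type nitrogen. This change bears directly on the measured step, because the group that entered in a 250-fold lower number from compound 1 to compound 2 (2.41 log units; beyond the scatter) is now the group leaving, while an aromatic ring enters instead. For the measured compounds named here, the only step in hand is therefore the one that brought the sulfate arm in, and compound 3 gives that arm up. A higher number is expected for compound 3 in this assay, with a 49-fold higher number from compound 2 to compound 3 (1.69 log units; beyond the scatter) as the anticipated step. The estimate for compound 3 is 3000 nM, within a range from 300 nM to 30000 nM.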

Compound 3, half-maximal effective concentration: 410 nM
Compound 3: middle estimate off by 7.3-fold (0.86 log units), on the high side; measured number inside the range.
By their numbers in this assay, from the lowest: compound 2; then compound 3; then compound 1.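

In this assay, the sulfate arm proves not to be the only route to a low number at this position: (1H-imidazol-1-yl)methyl in place of 2-(sulfooxy)ethoxy gives only a 6.7-fold higher number from compound 2 to compound 3 (0.83 log units; beyond the scatter) and so stays well clear of the starting point. Measured against the 1-(hydroxymethyl)-1-methylethyl group on the amide-type nitrogen, the 3-(1H-imidazol-1-yl)propyl arm still gives a 38-fold lower number from compound 1 to compound 3 (1.58 log units; beyond the scatter) even though compound 2 keeps the lowest number of the three. Nothing at hand gives a reason for either step.

The compounds shown leave open whether the imidazole ring itself is needed for this gain. A plain butyl chain, a terminal amine or a carboxylic acid on the same amide-type nitrogen could tell whether the number follows the ring or the arm.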